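This account rests on a few compounds, and the source may have more. Where it says the series, first, only, none or still open, it means among the compounds named here.

Compound 1 `CCN(CC)S(=O)(=O)c1ccc(S(=O)(=O)N2CCC[C@@H](C(=O)N3CCC(O)CC3)C2)cc1` stands weakest of the three measured compounds: in a functional assay on BXPC-3 cells (Homo sapiens) for inhibition, read by MTT assay, with a stated time of 7 days (on this read-out lower numbers stand for stronger inhibition and higher numbers for weaker inhibition), compound 1 gives 4710 nM, whereas compound 2 `CCN(CC)C(=O)c1ccc(S(=O)(=O)N2CCC[C@@H](C(=O)N3CCC(F)(F)CC3)C2)cc1` gives 240 nM and compound 3 `CC(C)CS(=O)(=O)c1ccc(S(=O)(=O)N2CCC[C@@H](C(=O)N3CCC(F)(F)CC3)C2)cc1` gives 311 nM. Compounds 2 and 3 differ from each other on an aromatic carbon, and there the change is a 1.3-fold higher number from compound 2 to compound 3 (0.11 log units; within the scatter). Compound 4 `CCN(CC)S(=O)(=O)c1ccc(S(=O)(=O)N2CCC[C@@H](C(=O)NC3CCOCC3)C2)cc1` differs from compound 1 at the carbonyl carbon instead: (oxan-4-yl)amino in place of 4-hydroxypiperidin-1-yl on a carbonyl carbon. Within the data shown here, no measured step touches this carbonyl carbon, since the one step available sits on an aromatic carbon, so the data give no direction for this change. For compound 4 the number is therefore expected to stay close to that of compound 1, with an expected step of a 1.3-fold lower number from compound 1 to compound 4 (0.13 log units; within the scatter). Compound 4 is estimated at 3500 nM, within 900 nM to 12000 nM.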

Compound 4, half-maximal inhibitory concentration: 8570 nM
Compound 4: middle estimate off by 2.4-fold (0.39 log units), on the low side; the measured number falls inside the stated range.
By their numbers in this assay, from the lowest: compounds 2 and 3 (each within the scatter of the next); then compounds 1 and 4 (each within the scatter of the next).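

Among these compounds, this is the first measured step at the carbonyl carbon: with the same atoms joined differently, (oxan-4-yl)amino in place of 4-hydroxypiperidin-1-yl gives a 1.8-fold higher number from compound 1 to compound 4 (0.26 log units; within the scatter) in this assay. This one exchange therefore does not separate compound 1 from compound 4 on this read-out. No measurement shown here accounts for this result.

Still open, on these data alone, is how a group of a different kind on this carbonyl carbon, such as an open-chain dimethylamino or a morpholin-4-yl ring, would read in this assay.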